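A few compounds are considered here, and "the series" means these few. Any claim that something is new, unique, unknown or untested is made for them only; others in the source may bear on it.

Working notes on the series.

Three compounds have been run in a functional assay on the whole organism (artery, strain albino) with Rattus norvegicus as the target, with a stated time of 600 min, at a dose of 10 mg/kg by the oral route; a lower number here means less inhibition, a higher number more inhibition at the dose given (going by the name of the read-out). Compound 1 `CC1=C(C(=O)Nc2ccc(F)cc2)C(c2ccc([N+](=O)[O-])cc2)N=C(SCc2cccc(Cl)c2)N1` gives 16.4% in this assay. Compound 2 `CC1=C(C(=O)Nc2ccc(F)cc2)C(c2ccc([N+](=O)[O-])cc2)N=C(SCc2ccc(Cl)cc2)N1` gives 28.2%. Compound 3 `CC1=C(C(=O)Nc2ccc([N+](=O)[O-])cc2)C(c2cccc([N+](=O)[O-])c2)N=C(SCc2cccc(Cl)c2)N1` gives 19%; the gaps from compound 3 to compound 1 and to compound 2 both fall within the scatter, so no order among these three follows from them.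

One single-site change is measured: from compound 1 to compound 2 the difference is 4-chlorophenyl in place of 3-chlorophenyl on a saturated chain carbon bound to a sulfur, and in this assay it produced a number 11.8 percentage points higher from compound 1 to compound 2 (beyond the scatter).

Compound 4 `CC1=C(C(=O)Nc2ccc([N+](=O)[O-])cc2)C(c2cccc([N+](=O)[O-])c2)N=C(SCc2ccc(Cl)cc2)N1` has not been measured. It differs from compound 3 by 4-chlorophenyl in place of 3-chlorophenyl on a saturated chain carbon bound to a sulfur, which is the same change made between compound 1 and compound 2, at the same place. The cores of compound 3 and compound 1 differ in more than one place, and that difference is not broken down here.

The expectation for compound 4 rests on one pair only. Because the change gave a number 11.8 percentage points higher from compound 1 to compound 2 (beyond the scatter) on the core of compound 1, a step of similar direction is expected on the core of compound 3, estimated as a number 10 percentage points higher from compound 3 to compound 4 (within the scatter), held slightly smaller since a single occurrence carries no weight on how far it transfers. Compound 4 is therefore expected to give about 29% in this assay, estimated between 16% and 42%.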

Compound 4, a percentage reported as inhibition, in the whole organism at one dose (the size of the read-out at that dose, not a potency): 26.2%
Compound 4: middle estimate off by 2.8 percentage points, on the high side; the measured number falls inside the stated range.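

On the core of compound 3, 4-chlorophenyl in place of 3-chlorophenyl on a saturated chain carbon bound to a sulfur gives, in this assay, a number 7.2 percentage points higher from compound 3 to compound 4 (within the scatter) on its own. This does not establish a real gain on the core of compound 3, and two pairs say nothing about how the change would behave on any further core, nor which of the several differences between the two cores might matter for its size. What can be said is that the step points the same way on both cores and that its size cannot be told apart between them: the same change on two cores in this assay, a number 11.8 percentage points higher (beyond the scatter) from compound 1 to compound 2 and a number 7.2 percentage points higher (within the scatter) from compound 3 to compound 4, 4.6 percentage points apart, within the scatter of two such steps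

The compounds shown leave open whether the step belongs to the chlorine itself or would also appear with another group on the benzyl ring, such as methoxy or trifluoromethyl, or with a longer chain in place of the benzyl group on the sulfur. They also leave open how the step would fare on a core carrying a polar group such as an amine or a carboxylic acid in place of the nitro groups and the fluorine seen so far, and whether it would hold at another dose or time in the same whole-organism setting.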